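Replacing the methoxyphenyl arm with a chlorophenyl arm

This account rests on a few compounds, and the source may have more. Where it says the series, first, only, none or still open, it means among the compounds named here.

Measured compounds:
- compound 1, `CCOC(=O)c1cnc(-c2ccccc2)nc1NN1C(=O)C=C(C)C1=O`: 100 nM
- compound 2, `CCOC(=O)c1cnc(-c2cnc3ccccc3c2)nc1NN1C(=O)C=C(C)C1=O`: 6000 nM
- compound 3, `CCOC(=O)c1cnc(-c2cccc(OC)c2)nc1NN1C(=O)C=C(C)C1=O`: 5000 nM

Of the compounds shown here, three sharing one core have been measured in a functional assay on Jurkat cells for inhibition of nuclear factor NF-kappa-B complex (Homo sapiens); on this read-out higher numbers stand for weaker inhibition and lower numbers for stronger inhibition. Compound 1 gives the lowest number of the three. Compound 3 stands second highest: its nearest neighbour is compound 2, whose value lies within the scatter of compound 3, while its furthest is compound 1, reached by a 50-fold higher number from compound 1 to compound 3 (1.70 log units; beyond the scatter) when read in the other direction.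

Compound 4, `CCOC(=O)c1cnc(-c2ccc(Cl)cc2)nc1NN1C(=O)C=C(C)C1=O`, has not been measured. Its difference from compound 3 is 4-chlorophenyl in place of 3-methoxyphenyl on an aromatic carbon.

Among the compounds with values here, two measured steps bear on this. The step of a 50-fold higher number from compound 1 to compound 3 (1.70 log units; beyond the scatter) shows what the methoxy group cost when it entered; the step of a 60-fold higher number from compound 1 to compound 2 (1.78 log units; beyond the scatter) shows that a larger aromatic group in the same place also cost a great deal. Within the data shown here, compound 4 removes the methoxy group and brings in a chlorine on a phenyl ring, a change for which no measured step exists.

The account therefore expects a lower number for compound 4 than for compound 3, with the step from compound 3 to compound 4 estimated at a 13-fold lower number from compound 3 to compound 4 (1.10 log units; beyond the scatter). Compound 4 is expected to give 400 nM in this assay, with a range from 80 nM to 2500 nM.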

Compound 4, half-maximal inhibitory concentration: 300 nM
For compound 4 the middle estimate is 1.3-fold (0.12 log units) above the measured one, within the range that was stated.
By their numbers in this assay, from the lowest: compound 1; then compound 4; then compounds 3 and 2 (each within the scatter of the next).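

In this assay, the aromatic carbon between two ring nitrogen atoms can carry a substituted phenyl arm without the full loss seen for the 3-methoxyphenyl and quinolin-3-yl arms: the 4-chlorophenyl arm gives a 17-fold lower number from compound 3 to compound 4 (1.22 log units; beyond the scatter), and against the larger quinolin-3-yl arm it gives a 20-fold lower number from compound 2 to compound 4 (1.30 log units; beyond the scatter). Substitution on the phenyl arm is still not free, since the chloro group gives a 3.0-fold higher number from compound 1 to compound 4 (0.48 log units; beyond the scatter), a modest step that leaves the unsubstituted phenyl of compound 1 with the lowest number of the four, yet one far smaller than a 50-fold higher number from compound 1 to compound 3 (1.70 log units; beyond the scatter). No measurement available here speaks to why these arms differ so widely in this assay.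

The step between compound 3 and compound 4 changes both the substituent and where it sits on the phenyl ring, so the contribution of each stays unresolved, and a 3-chlorophenyl or 4-methoxyphenyl arm would be needed to separate them. On these data alone, how the position responds to a substituent of another kind, such as an amine or a carboxylic acid on the phenyl ring, also remains open.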